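Amide nitrogen substituent and tolerated concentration in the series

The compounds below may be only part of what the source reports. "The series", "measured", "known", "first", "only" and "open" are said of these compounds alone.

Measured compounds:
compound 1 `COc1ccc(NC(=O)COc2cc(C)nc3ccc(OC)cc23)cc1` gives only a limit in an ADME assay on HepG2 cells (Homo sapiens) for cytotoxicity, read by trypan blue exclusion, with a stated time of 48 h, in the presence of a further agent that is not named here (a higher number here means that more compound is tolerated, a lower number that less compound is tolerated), > 142000 nM.
compound 2 `COc1ccc2nc(C)cc(OCC(=O)Nc3ccc(Cl)cc3)c2c1` gives 71100 nM in this assay.

Going by the values given here, compound 2 holds the only number in this assay; the other value shown is a limit. The limit of compound 1 is the limit of > 142000 nM in this assay, at which 1 of the 2 values shown sits. Among the compounds with values here, the single measured step, an at least 1.9-fold lower number from compound 1 to compound 2 (0.30 log units; that floor lies within the scatter), has its floor within the scatter and fixes no direction. Compound 3 `COCCNC(=O)COc1cc(C)nc2ccc(OC)cc12` differs from compound 2 by 2-methoxyethyl in place of 4-chlorophenyl on an amide-type nitrogen. Within the data shown here, no measured step touches the amide nitrogen substituent, so the expectation rests loosely on the two values shown. The expected step is a 1.8-fold higher number from compound 2 to compound 3 (0.26 log units; within the scatter), toward more compound tolerated. The estimate for compound 3 is 130000 nM, within 50000 nM to 300000 nM.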

Compound 3, half-maximal cytotoxic concentration: > 164000 nM
Compound 3: a limit, no number; the forecaster's own chance of this, stated with the estimate: 45%; middle value at least 1.2-fold (0.10 log units) from the limit.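

Going by these compounds alone, putting 2-methoxyethyl in place of 4-chlorophenyl on the amide-type nitrogen gives an at least 2.3-fold higher number from compound 2 to compound 3 (0.36 log units; beyond the scatter) in this assay, the only readable step that lies beyond the scatter and so fixes a direction. Compound 3 gives only a limit: the limit of > 164000 nM in this assay, at which 1 of the 3 values shown sits.
The step from compound 1 to compound 3 cannot be read.

On these data alone, whether the aromatic ring, the chlorine or the chain oxygen carries this step stays open. Also open, as far as these compounds go, is how a plain alkyl chain, a longer chain, an amine or a carboxylic acid on this nitrogen would read in this assay.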